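The source may hold more compounds than are shown below. What is called first, only, known or untested is meant among the compounds shown, and "the series" means these compounds.

In a functional assay on PC-3 cells (Homo sapiens) for inhibition, read by colorimetric assay and MTT assay, with a stated time of 72 h (a higher number here means a weaker inhibitor, a lower number a stronger inhibitor), compound 3 `C=CCCCCOc1ccccc1-c1cnc(S(=O)(=O)c2ccccc2)n1C` gives 33000 nM. Compound 1 `C=CCCCCOc1ccccc1-c1cnc(OCCCC=C)n1C` gives 28000 nM, and the step is a 1.2-fold higher number from compound 1 to compound 3 (0.07 log units; within the scatter), so these two stand level. Compound 2 `Cn1c(-c2ccccc2O)cnc1S(=O)(=O)c1ccccc1` reads > 100000 nM, which is a limit of the assay and not a number.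

Compound 4 `C=CCCOc1ccccc1-c1cnc(S(=O)(=O)c2ccccc2)n1C` shortens the chain of compound 3: vinyl in place of but-3-en-1-yl on a saturated chain carbon, two bonds along the chain from an oxygen on an aromatic ring. In other words, (hex-5-en-1-yl)oxy becomes (but-3-en-1-yl)oxy. The measured step that bears on this is the one that puts hex-5-en-1-yl in place of hydrogen on that oxygen, an at least 3.0-fold lower number from compound 2 to compound 3 (0.48 log units; beyond the scatter). Compound 4 keeps a shorter chain, so only a small step towards a higher number is expected in this assay. The expected change is a 1.4-fold higher number from compound 3 to compound 4 (0.13 log units; within the scatter). For compound 4, the estimated value is 45000 nM, with a range of 20000 nM to 100000 nM.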

Compound 4, half-maximal inhibitory concentration: 42000 nM
For compound 4 the middle estimate is 1.1-fold (0.03 log units) above the measured one; the range from low to high includes it.
By their numbers in this assay, from the lowest: compounds 1, 3 and 4 (each within the scatter of the next). At a limit, above all of these: compound 2.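

Cutting the chain from (hex-5-en-1-yl)oxy to (but-3-en-1-yl)oxy leaves the reading in this assay level: a 1.3-fold higher number from compound 3 to compound 4 (0.10 log units; within the scatter). The shorter chain on that oxygen still reads below the compound with hydrogen there, an at least 2.3-fold lower number from compound 2 to compound 4 (0.37 log units; beyond the scatter), so across these two chain lengths the length makes no clear difference. That comparison rests on a limit, not a number, for compound 2: the limit of > 100000 nM in this assay, at which 1 of the 4 values shown sits.

From the compounds shown here alone, whether a methyl group on that oxygen, a longer chain, or an amine at the chain's end would move the reading stays open. Going by these compounds, the step from hydrogen to a chain has a measured value on one side only, so its full size also stays open.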